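This account rests on a few compounds, and the source may have more. Where it says the series, first, only, none or still open, it means among the compounds named here.

Compound 1 `CCCCCCCCCCCC(=O)Nc1nnc(S[C@@H]2O[C@H](COC(C)=O)[C@H](OC(C)=O)[C@H](OC(C)=O)[C@H]2OC(C)=O)s1` and compound 2 `CCCCCCCCCCCCCC(=O)Nc1nnc(S[C@@H]2O[C@H](COC(C)=O)[C@H](OC(C)=O)[C@H](OC(C)=O)[C@H]2OC(C)=O)s1` share one core and differ only in the length of the amide chain. In a functional assay on DU-145 cells (Homo sapiens) for cytotoxicity, read by MTT assay, with a stated time of 24 h (a higher number here means a weaker inhibitor, a lower number a stronger inhibitor), compound 1 gives 16900 nM, and compound 2 gives 34700 nM. Between them stands the change (hydrogen in place of ethyl on a saturated chain carbon, ten or more bonds along the chain from a carbonyl carbon), which made a 2.1-fold lower number from compound 2 to compound 1 (0.31 log units; beyond the scatter). Compound 3 `CCCCCCCCCCCCCCCC(=O)Nc1nnc(S[C@@H]2O[C@H](CO)[C@H](O)[C@H](O)[C@H]2O)s1` is built on a second core; the difference between the two cores is not broken down here. In this assay compound 3 is reported as "not active" (no number reported), and no number is given for it. Compound 4 `CCCCCCCCCCCCCC(=O)Nc1nnc(S[C@@H]2O[C@H](CO)[C@H](O)[C@H](O)[C@H]2O)s1` stands to compound 3 as compound 1 stands to compound 2: the change from compound 3 to compound 4 is hydrogen in place of ethyl on a saturated chain carbon, ten or more bonds along the chain from a carbonyl carbon, the same kind of change at the same place as before. For the measured compounds named here, since compound 3 has no number, no size of step can be set beside the earlier one; what can be said is that the earlier change gave only a modest lowering on the core of compound 1 and compound 2, while compound 3 shows no measurable activity on its own core. On that ground compound 4 is expected to remain a weak inhibitor, with a real chance that the assay again returns no number. Compound 4 is expected to come in near 70000 nM, somewhere between 20000 nM and 250000 nM.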

Compound 4, half-maximal inhibitory concentration: "not active" (no number reported)
No number was reported for compound 4; the estimate stays without a comparison.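

In this assay compound 3 and compound 4 both stand without a number, so no step can be read between them or set beside the earlier chain change. No measurement shown here bears on this result. The compounds shown leave open whether the chain change has any effect on the core of compound 3 and how that core compares with the core of compound 1.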